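A Second Methoxy Group Carried Across Two Cores

The source may report more compounds than this note shows. Statements on the series, on what has been measured and on what is new or still open speak of the compounds shown alone.

The study sets out compound 1, `CNc1nc(Nc2ccc(C)c([N+](=O)[O-])c2)ncc1C(=O)Nc1cc(NC(=O)c2ccc(OC)cc2)ccc1C`, and compound 2, `CNc1nc(Nc2ccc(C)c([N+](=O)[O-])c2)ncc1C(=O)Nc1cc(NC(=O)c2ccc(OC)c(OC)c2)ccc1C`, which share one core and differ only as told by methoxy in place of hydrogen on an aromatic carbon. In an ADME assay on BaF3 cells (Mus musculus) for antiproliferative activity, read by CellTiter-Glo and CCK-8 assay, with a stated time of 72 h (on this read-out higher numbers stand for weaker inhibition of growth and lower numbers for stronger inhibition of growth), compound 1 reports only a limit of the assay, > 10000 nM. In this assay compound 2 gives 7300 nM. The measured step between the two is an at least 1.3-fold lower number from compound 1 to compound 2 (0.13 log units; that floor lies within the scatter).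

Compound 3, `CNc1nc(Nc2ccc(C)c(N)c2)ncc1C(=O)Nc1cc(NC(=O)c2ccc(OC)cc2)ccc1C`, carries the second core; how the two cores differ is told by amino in place of nitro on an aromatic carbon. In this assay compound 3 likewise reports only a limit of the assay, > 10000 nM. The step that the two limits leave unreadable from compound 1 to compound 3 cannot be read because of the limit of > 10000 nM in this assay, at which 2 of the 3 values shown sit.

Compound 4, `CNc1nc(Nc2ccc(C)c(N)c2)ncc1C(=O)Nc1cc(NC(=O)c2ccc(OC)c(OC)c2)ccc1C`, stands to compound 3 as compound 2 stands to compound 1. The change is methoxy in place of hydrogen on an aromatic carbon, and since the place is described in the same words on both cores, this is the same change rather than merely the same kind of change. On the first core its size was an at least 1.3-fold lower number from compound 1 to compound 2 (0.13 log units; that floor lies within the scatter), a step that sits within the usual scatter.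

For compound 4 the account therefore expects in this assay a value near 8000 nM, with a range from 3000 nM to 20000 nM, which would mean an expected step of an at least 1.2-fold lower number from compound 3 to compound 4 (0.09 log units; that floor lies within the scatter). This expectation rests on the single measured size of the change, an at least 1.3-fold lower number from compound 1 to compound 2 (0.13 log units; that floor lies within the scatter). It also rests on compound 3 having given only a limit, > 10000 nM, so a limit for compound 4 remains about as likely as a number.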

Compound 4, concentration for 50% growth inhibition: > 10000 nM
Compound 4 ended at the assay's limit; the forecaster's own chance of this, stated with the estimate: 50%; at least 1.2-fold (0.09 log units) between middle value and limit.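

In this assay compound 4 gives > 10000 nM, which is a limit of the assay and not a number. Among these compounds, the methoxy change therefore has no measurable size on the core of compound 3, and neither the step it makes there nor the step between compound 1 and compound 3 can be read, because both ends of each step are limits: the limit of > 10000 nM in this assay, at which 3 of the 4 values shown sit. The one new step that can be read is an at least 1.3-fold higher number from compound 2 to compound 4 (0.13 log units; that floor lies within the scatter), which is amino in place of nitro on an aromatic carbon, and since that floor lies within the scatter, and the methoxy step on the first core does too, the series shows neither that the change carries from one core to the other nor that it fails to.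

The compounds shown leave open whether the added methoxy does anything at all on either core, since no readable step for it goes beyond the scatter. They also leave open whether a different group in place of that methoxy, such as an ethoxy, a morpholine or a carboxylic acid, would bring the core of compound 3 off the limit and give a number that could be compared.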